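A few compounds are considered here, and "the series" means these few. Any claim that something is new, unique, unknown or untested is made for them only; others in the source may bear on it.

Measured in a functional assay on HeLa cells (Homo sapiens) for cytotoxicity, read by MTT assay; a lower number here means a stronger inhibitor, a higher number a weaker inhibitor:
- compound 1 `CC(C)=CC[C@@H](OC(=O)CCO)C1=CC(=O)c2c(O)ccc(O)c2C1=O`: 67600 nM
- compound 2 `CC[C@](C)(O)CC(=O)O[C@H](CC=C(C)C)C1=CC(=O)c2c(O)ccc(O)c2C1=O`: 30200 nM
- compound 3 `CCCCCCC(C)(O)CC(=O)O[C@H](CC=C(C)C)C1=CC(=O)c2c(O)ccc(O)c2C1=O`: > 100000 nM

Compound 3 stands at > 100000 nM, which is a limit of this assay and not a number.

Compound 4 `CCCC(CC(=O)O[C@H](CC=C(C)C)C1=CC(=O)c2c(O)ccc(O)c2C1=O)OC(C)=O` has not yet been measured. It differs from compound 3 by 1-acetoxybutyl in place of 1-hydroxy-1-methylheptyl on a saturated chain carbon bound to a carbonyl carbon, with 1-acetoxybutyl in place of 1-hydroxy-1-methylheptyl on a saturated chain carbon bound to a carbonyl carbon.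

The most relevant measured change is an at least 3.3-fold higher number from compound 2 to compound 3 (0.51 log units; beyond the scatter), where 1-hydroxy-1-methylheptyl replaced 1-hydroxy-1-methylpropyl. The other steps, a 2.2-fold lower number from compound 1 to compound 2 (0.35 log units; beyond the scatter) and an at least 1.4-fold higher number from compound 1 to compound 3 (0.17 log units; that floor lies within the scatter), show that the shorter-chain compounds 1 and 2 both gave numbers. A lower number is expected for compound 4, though with limited confidence. This expectation rests on compound 2, which carries 1-hydroxy-1-methylpropyl and gives 30200 nM. The expected step is an at least 2.5-fold lower number from compound 3 to compound 4 (0.39 log units; beyond the scatter).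

The estimate for compound 4 is 40000 nM, with an expected range of 15000 nM to 90000 nM.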

Compound 4, half-maximal inhibitory concentration: 51200 nM
Estimate against measurement, compound 4: 1.3-fold (0.11 log units) below; measured number inside the range.
By their numbers in this assay, from the lowest: compounds 2, 4 and 1 (each within the scatter of the next, the first and the last beyond it). At a limit, above all of these: compound 3.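

With 1-acetoxybutyl, which has no hydrogen-bond donor, compound 4 still gives a number at this place on a saturated chain carbon bound to a carbonyl carbon, so a hydroxyl in this group is not required for one. The steps of a 1.7-fold higher number from compound 2 to compound 4 (0.23 log units; within the scatter) and a 1.3-fold lower number from compound 1 to compound 4 (0.12 log units; within the scatter) show no separation from the two hydroxyl compounds. Compound 3 is at a limit, so an at least 1.9-fold lower number from compound 3 to compound 4 (0.29 log units; that floor lies within the scatter) gives only a floor: the limit of > 100000 nM in this assay, at which 1 of the 4 values shown sits.

Still open, from the compounds shown here alone, is whether a longer chain carrying the acetoxy group would give a number, and how an amine in its place would compare.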